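Compound 3 to compound 4: methylsulfonyl in place of cyano

The source may hold more compounds than are shown below. What is called first, only, known or untested is meant among the compounds shown, and "the series" means these compounds.

In a physicochemical assay for solubility, read by spectrophotometry, in phosphate buffer, with a stated time of 18 h, at pH 7.4 (a lower number here means a less soluble compound, a higher number a more soluble compound), compound 1 `Cc1ccccc1-c1nc2c(c(C)nn2-c2ccccc2)c(-c2ccccc2O)c1C#N` gives 21000 nM and sits highest of the three numbers in hand. Compound 2 `CCCc1ccc(-c2nc3c(c(C)nn3-c3ccccc3)c(-c3ccccc3O)c2C#N)cc1` follows with 6500 nM as the middle number. Compound 3 `Cc1nn(-c2ccccc2)c2nc(-c3ccc(C#N)cc3)c(C#N)c(-c3ccccc3O)c12` gives 1700 nM and is the lowest, with its steps to both others beyond the scatter.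

The next compound, compound 4 `Cc1nn(-c2ccccc2)c2nc(-c3ccc(S(C)(=O)=O)cc3)c(C#N)c(-c3ccccc3O)c12`, carries methylsulfonyl in place of cyano on an aromatic carbon, para to a large group, and is otherwise unchanged: methylsulfonyl in place of cyano on an aromatic carbon describes the swap.

All three measured steps change the group at this same place. The step of a 3.2-fold lower number from compound 1 to compound 2 (0.51 log units; beyond the scatter) is modest, the step of a 12-fold lower number from compound 1 to compound 3 (1.09 log units; beyond the scatter) is large, and the step of a 3.8-fold lower number from compound 2 to compound 3 (0.58 log units; beyond the scatter) is modest. The last of these bears most directly, since only the group on that aromatic carbon changes. Within the data shown here, these steps show that the number can move with changes here, but no measured compound carries methylsulfonyl, so they set no direction for the new swap. In this assay no step beyond the scatter is therefore expected, although a modest step either way remains possible.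

The expected change is a 1.1-fold lower number from compound 3 to compound 4 (0.05 log units; within the scatter) on this estimate. For compound 4 the estimated value is 1500 nM with an expected range from 500 nM to 4500 nM as its span.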

Compound 4, solubility: 5000 nM
Compound 4: middle estimate off by 3.3-fold (0.52 log units), on the low side, outside the stated range (above it).
By their numbers in this assay, from the lowest: compound 3; then compounds 4 and 2 (each within the scatter of the next); then compound 1.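

In this assay, among these compounds, the swap at this aromatic carbon is not neutral: a 2.9-fold higher number from compound 3 to compound 4 (0.47 log units; beyond the scatter) separates methylsulfonyl from cyano by a step beyond the scatter, which the earlier compounds, none carrying methylsulfonyl, could not show. The comparison with propyl reads differently, since a 1.3-fold lower number from compound 2 to compound 4 (0.11 log units; within the scatter) leaves methylsulfonyl and propyl within the scatter of each other, so that among the three groups on this ring only cyano stands apart, while a 4.2-fold lower number from compound 1 to compound 4 (0.62 log units; beyond the scatter) keeps the 2-methylphenyl group of compound 1 as the highest number of the four. Nothing measured here accounts for any of these differences.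

The compounds shown give only cyano, propyl and methylsulfonyl on this aromatic carbon, so how an amine, a carboxylic acid or a longer chain would read there in this assay remains open. Also open, going by these compounds, is whether methylsulfonyl in place of cyano gives a step of similar size when the rest of the shared core carries other groups, such as a methoxy group in place of the hydroxyl on the phenol ring.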